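Fluoro for methyl on the aromatic ring of compound 2

The source may hold more compounds than are shown below. What is called first, only, known or untested is meant among the compounds shown, and "the series" means these compounds.

Two hydroxamic acids on a shared core have been measured. Compound 1 `O=C(CCC1=CCN(CCCc2ccc(Br)cc2)C1=O)NO` carries a three-carbon tether to a bromophenyl ring; compound 2 `Cc1ccc(CN2CC=C(CCC(=O)NO)C2=O)cc1` carries a methylbenzyl arm. In a functional assay on HCT-15 cells (Homo sapiens) for inhibition, read by sulforhodamine B assay (a lower number here means a stronger inhibitor of growth, a higher number a weaker inhibitor of growth), compound 1 gives 5100 nM and, in this assay, compound 2 gives 4720 nM. Compound 2 has the lower of the two numbers, yet the gap to compound 1 is within the scatter, so no order between them can be read.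

Compound 3 `O=C(CCC1=CCN(Cc2ccc(F)cc2)C1=O)NO` keeps the whole of compound 2 except for one change: fluoro in place of methyl on an aromatic carbon. Within the data shown here, no pair of measured compounds differing in a single place exists here, so this step has no direct precedent in the set.

Expectation: since compound 1 at 5100 nM and compound 2 at 4720 nM fall within the scatter of each other despite quite different arms, a single small swap on the aromatic ring is expected to produce no step beyond the scatter, a 1.0-fold lower number from compound 2 to compound 3 (0.00 log units; within the scatter), in either direction. Compound 3 is therefore expected to give about 4700 nM, with a range from 2400 nM to 9500 nM.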

Compound 3, concentration for 50% growth inhibition: 4070 nM
Compound 3: the middle estimate sits 1.2-fold (0.06 log units) above what was measured, within the range that was stated.
By their numbers in this assay, from the lowest: compounds 3, 2 and 1 (each within the scatter of the next).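

Among these compounds, compound 2 and compound 3 are the only pair that differs in one place, and in this assay fluoro in place of methyl on an aromatic carbon, para to a large group, gives a 1.2-fold lower number from compound 2 to compound 3 (0.06 log units; within the scatter) as the whole of the step. At this position, methyl and fluoro therefore cannot be told apart by this read-out, although that holds for these two groups alone and not for the position in general. No measurement at hand bears on why the two groups read alike.

Still open, going by these compounds, is whether a methoxy, a trifluoromethyl, an amine or a carboxylic acid on this same aromatic carbon, or plain hydrogen there, would also stay within the scatter of compound 2. Also open, on these data alone, is what the longer tether of compound 1 contributes on its own, since that compound differs from compound 2 in more than one place, and a bromo on the benzyl arm would separate the ring substituent from the chain length.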